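The source may report more compounds than this note shows. Statements on the series, on what has been measured and on what is new or still open speak of the compounds shown alone.

In an ADME assay on the whole organism with Oryza sativa as the target, tested at 1 uM (on this read-out higher numbers stand for a weaker effect at the one concentration tested and lower numbers for a stronger effect), compound 1, with structure `C[C@@H](NC(=O)Nc1ccccc1Cl)c1ccccc1`, gives 103%. Compound 2, `C[C@H](NC(=O)Nc1ccccc1Cl)c1ccccc1`, shares every atom and bond with it; the two differ only in the configuration drawn at one saturated chain carbon, (the two compounds have the same atoms and bonds and differ only in configuration as drawn: 1 of 1 stereo elements differ; a stereocentre at a saturated chain carbon is drawn S in compound 2 and R in compound 1). In this assay compound 2 gives 104%, and the step of a number 1 percentage points higher from compound 1 to compound 2 (within the scatter) stays inside the usual spread of repeated measurements, which fits (the fact that compounds 1 and 2 differ only in the configuration as drawn). Compound 3, `C[C@H](NC(=O)Nc1cccc(Cl)c1Cl)c1ccccc1`, arises from compound 2 through (chloro in place of hydrogen on an aromatic carbon). In this assay compound 3 gives 100%, so the step of a number 4 percentage points lower from compound 2 to compound 3 (within the scatter) also falls inside that ordinary spread.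

Compound 4, `C[C@@H](NC(=O)Nc1ccc(Cl)cc1Cl)c1ccccc1`, has not yet been measured. It comes from compound 1 through the same kind of change, (chloro in place of hydrogen on an aromatic carbon). The surroundings of the entering chloro are not identical, though: in compound 3 it stands ortho to a chloro group and meta to a large group, whereas in compound 4 it stands meta to a chloro group and para to a large group. Among the measured compounds shown here, the only measured guide is that the same kind of change, from compound 2 to compound 3, gave a step within the scatter.

For compound 4 the expected step is a number 3 percentage points lower from compound 1 to compound 4 (within the scatter), and that expectation rests on the measured step of a number 4 percentage points lower from compound 2 to compound 3 (within the scatter). Compound 4 is therefore estimated at 100%, most plausibly between 91% and 109%.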

Compound 4, a percentage reported as activity, at one concentration (the size of the read-out at that concentration, not a potency): 99%
For compound 4 the middle estimate is 1 percentage points above the measured one; the range from low to high includes it.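

In this assay the new chloro on the aromatic ring gives a number 4 percentage points lower from compound 1 to compound 4 (within the scatter), and this can be set beside the same change made on the other core: the same change on two cores in this assay, a number 4 percentage points lower (within the scatter) from compound 2 to compound 3 and a number 4 percentage points lower (within the scatter) from compound 1 to compound 4, 0 percentage points apart, within the scatter of two such steps. For these two pairs, then, the change carries over from one core to the other in a simple sense: on both cores, adding a chloro gives a step no larger than the ordinary spread of repeated measurements, even though the chloro enters at a different place on the ring in each pair and the two cores differ in the configuration drawn at the saturated chain carbon. Among the compounds shown here, this does not show that the chloro has a transferable effect, since neither step can be told apart from scatter, so the agreement is between two small steps and rests on only two pairs.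

The compounds shown leave open whether another group on this aromatic ring, such as a methoxy group, an amine or a carboxylic acid, would give a step beyond the scatter. They also leave open what a longer chain on the saturated carbon would do in this assay, and whether any such step would then carry over between the cores.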